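The source may report more compounds than this note shows. Statements on the series, on what has been measured and on what is new or still open speak of the compounds shown alone.

Of the compounds shown here, two from one series have been measured so far. Compound 1 `O=C([C@@H]1CCCN(S(=O)(=O)c2ccc(S(=O)(=O)N3CC[C@@H](O)C3)cc2)C1)N1CCC(F)(F)CC1` is one of them; in a functional assay on MIA PaCa-2 cells (Homo sapiens) for inhibition, read by MTT assay, with a stated time of 7 days (on this read-out lower numbers stand for stronger inhibition and higher numbers for weaker inhibition), compound 1 gives 210 nM. Compound 2 `CCN(CC)S(=O)(=O)c1ccc(S(=O)(=O)N2CCC[C@@H](C(=O)N3CCOCC3)C2)cc1` is the other, and in this assay compound 2 gives 350 nM. Of these two numbers, that of compound 2 is the larger, but the gap to compound 1 lies within the usual scatter of repeated measurements, so nothing separates the two compounds on these data.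

Compound 3 `CCN(CC)S(=O)(=O)c1ccc(S(=O)(=O)N2CCC[C@@H](C(=O)N3CC[C@@H](OC)C3)C2)cc1` has not yet been measured. It differs from compound 2 in one place: 3-methoxypyrrolidin-1-yl in place of morpholin-4-yl on a carbonyl carbon. For the measured compounds named here, no pair of measured compounds differs only in this way, so there is no measured step to lean on, and compound 1 differs from compound 2 in several places at once, which gives no clean guidance. The expected step is therefore a 1.2-fold lower number from compound 2 to compound 3 (0.07 log units; within the scatter), meaning no change beyond the scatter in this assay, in either direction. Compound 3 is thus estimated at 300 nM, with a range from 120 nM to 800 nM.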

Compound 3, half-maximal inhibitory concentration: 3910 nM
Compound 3: middle estimate off by 13-fold (1.12 log units), on the low side, outside the stated range (above it).
By their numbers in this assay, from the lowest: compounds 1 and 2 (each within the scatter of the next); then compound 3.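

The carbonyl carbon on the saturated ring proves to be a sensitive position: in this assay, placing 3-methoxypyrrolidin-1-yl where morpholin-4-yl stood gives an 11-fold higher number from compound 2 to compound 3 (1.05 log units; beyond the scatter), a large weakening of inhibition. The earlier compounds shown here gave no sign of this, since their two numbers could not be told apart, and here a clear shift appears although both groups have 0 hydrogen-bond donors, 1 hydrogen-bond acceptor and no net charge. The swap changes several things at once, namely the ring size, the heavy-atom count (6 to 7) and the presence of a defined stereocentre, and no measured evidence bears on why the number rises.

A plain pyrrolidin-1-yl group, a piperidin-1-yl group or the opposite arrangement at the methoxy-bearing carbon would help show which of these differences matters, and the compounds shown leave that open. As far as these compounds go, it also remains open whether the same swap would produce a step of similar size on the core of compound 1.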